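Compound 3: a chlorine swap on the active hydrazone

The compounds below may be only part of what the source reports. "The series", "measured", "known", "first", "only" and "open" are said of these compounds alone.

Measured so far:
compound 1 `Cn1c(=O)c(=O)n(C2CCCC2)c2nc(N/N=C/c3ccccc3)ncc21` gives > 100000 nM (a limit)
compound 2 `Cn1c(=O)c(=O)n(C2CCCC2)c2nc(N/N=C/c3ccc(F)cc3F)ncc21` gives 18300 nM (a number)

In a functional assay on A549 cells (Homo sapiens) for antiproliferative activity, read by MTT assay (a lower number here means a stronger inhibitor, a higher number a weaker inhibitor), compound 1 gives > 100000 nM as a limit of the assay and not a number. In this assay, among the measured compounds shown here, compound 2 gives 18300 nM as the only true number so far. Compound 2 can so far be compared only with compound 1.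

Compound 3 `Cn1c(=O)c(=O)n(C2CCCC2)c2nc(N/N=C/c3ccccc3Cl)ncc21` is still unmeasured. It carries 2-chlorophenyl in place of 2,4-difluorophenyl on a carbon with a double bond to nitrogen.

For the measured compounds named here, the only measured step bearing on this is an at least 5.4-fold lower number from compound 1 to compound 2 (0.73 log units; beyond the scatter) and it replaces an unsubstituted phenyl, whereas compound 3 keeps halogen on the phenyl as compound 2 does, so a step of that kind is not expected here. One step gives no rule for exchanging fluorine for chlorine, so the expectation in this assay is for no change beyond the scatter, with a slight lean toward a higher number. The expected step is a 1.4-fold higher number from compound 2 to compound 3 (0.14 log units; within the scatter) in this estimate. The estimate for compound 3 is 25000 nM as the expected value, within an expected range of 8000 nM to 80000 nM overall.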

Compound 3, half-maximal inhibitory concentration: 9860 nM
Estimate against measurement, compound 3: 2.5-fold (0.40 log units) above; the measured number falls inside the stated range.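

In this assay, a halogen on the phenyl at this carbon with a double bond to nitrogen now gives a measurable gain in two forms, not one: chloro in place of hydrogen gives an at least 10-fold lower number from compound 1 to compound 3 (1.00 log units; beyond the scatter). The exchange of 2,4-difluorophenyl for 2-chlorophenyl gives a 1.9-fold lower number from compound 2 to compound 3 (0.27 log units; within the scatter), so compound 2 and compound 3 cannot be told apart, and the kind and number of halogens shown here make no readable difference. Compound 1 gives > 100000 nM, which is a limit and not a number, so the steps from it fix only a minimum size: the limit of > 100000 nM in this assay, at which 1 of the 3 values shown sits.

The exchange between compound 2 and compound 3 alters the kind of halogen, its number and its placing together, so none of these can be separated from the others in this series. As far as these compounds go, it also remains open whether halogen itself is what matters, or whether a methoxy group or a carboxylic acid on the same phenyl would likewise bring a number into the range of compound 2 and compound 3.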